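The source may hold more compounds than are shown below. What is called first, only, known or untested is meant among the compounds shown, and "the series" means these compounds.

Within an assay on cells for antagonist activity at transient receptor potential cation channel subfamily V member 4 (Homo sapiens), read by FLIPR and calcium flux, with a stated time of 10 min (on this read-out lower numbers stand for stronger inhibition and higher numbers for weaker inhibition), compound 3, `N#Cc1ccc(S(=O)(=O)[C@H]2CN(S(=O)(=O)c3ccc(Cl)cc3Cl)C[C@]2(O)CO)cc1`, gives 50 nM, the second highest of the three numbers seen so far. Its nearest neighbour is compound 1, `N#Cc1ccc(S(=O)(=O)[C@H]2CN(S(=O)(=O)c3ccc(Cl)cc3Cl)C[C@@]2(O)CO)cc1`, which gives 7.9 nM; the step of a 6.3-fold higher number from compound 1 to compound 3 (0.80 log units; beyond the scatter) is modest. Furthest away is compound 2, `N#Cc1ccc(S(=O)(=O)[C@@H]2CN(S(=O)(=O)c3ccc(Cl)cc3Cl)C[C@@]2(O)CO)cc1`, which gives 1590 nM; the step of a 32-fold lower number from compound 2 to compound 3 (1.50 log units; beyond the scatter) is large, the two being mirror images (the fact that compounds 2 and 3 differ only in the configuration as drawn).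

Compound 4, `N#Cc1ccc(S(=O)(=O)[C@@H]2CN(S(=O)(=O)c3ccc(Cl)cc3Cl)C[C@]2(O)CO)cc1`, is not yet measured. The change from compound 3 is the two compounds have the same atoms and bonds and differ only in configuration as drawn: 1 of 2 stereo elements differ; a stereocentre at a saturated ring carbon is drawn S in compound 3 and R in compound 4: the same ring carbon whose inversion separates compound 1 from compound 2 (the fact that compounds 1 and 2 differ only in the configuration as drawn). That measured step, a 200-fold higher number from compound 1 to compound 2 (2.30 log units; beyond the scatter), was large, so inversion at this centre carries most of the stereochemical sensitivity in this set, whereas the other centre, compared by the fact that compounds 1 and 3 differ only in the configuration as drawn, gave only the modest 6.3-fold higher number from compound 1 to compound 3 (0.80 log units; beyond the scatter).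

A large rise in this assay is therefore expected for compound 4, of order a 60-fold higher number from compound 3 to compound 4 (1.78 log units; beyond the scatter), though starting from the weaker diastereomer the loss may fall short of the full earlier size. The estimate for compound 4 is 3000 nM, with a range of 800 nM to 12000 nM.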

Compound 4, half-maximal inhibitory concentration: 159 nM
Compound 4: middle estimate off by 19-fold (1.28 log units), on the high side; the whole stated range lies above it.
By their numbers in this assay, from the lowest: compound 1; then compound 3; then compound 4; then compound 2.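

Inversion at the saturated ring carbon that separates compound 1 from compound 2 carries no fixed cost: the modest step of a 3.2-fold higher number from compound 3 to compound 4 (0.50 log units; beyond the scatter) stands against the large 200-fold higher number from compound 1 to compound 2 (2.30 log units; beyond the scatter), so its size depends on the configuration at the other stereocentre. The other stereocentre depends on the first in turn, since a 10-fold lower number from compound 2 to compound 4 (1.00 log units; beyond the scatter) runs in the opposite direction to a 6.3-fold higher number from compound 1 to compound 3 (0.80 log units; beyond the scatter), and the two centres therefore do not act independently. The second mirror-image pair is also well separated, with a 20-fold higher number from compound 1 to compound 4 (1.30 log units; beyond the scatter).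

The four compounds share the same atoms and bonds, so they give no reason for this coupling. As far as these compounds go, it remains open whether it would persist with an amine in place of the hydroxyl or a carboxylic acid in place of the nitrile.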